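This account rests on a few compounds, and the source may have more. Where it says the series, first, only, none or still open, it means among the compounds named here.

Measured compounds in a functional assay on NCI-H1299 cells (Homo sapiens) for antiproliferative activity, read by XTT assay, with a stated time of 72 h; on this read-out higher numbers stand for weaker inhibition and lower numbers for stronger inhibition:
- compound 1, `COc1ccc(-c2cc3ccccc3nc2/C=C/C(=O)c2ccccc2)cc1`: 1410 nM
- compound 2, `COc1ccc(-c2cc3ccccc3nc2/C=C/C(=O)c2ccc(F)cc2)cc1`: 820 nM
- compound 3, `COc1ccc(-c2cc3ccccc3nc2/C=C/C(=O)c2ccc([N+](=O)[O-])cc2)cc1`: 770 nM

All three share one core and differ only in the aromatic ring attached to the carbonyl. Compound 3 gives the lowest number of the three, but both steps that reach it, a 1.1-fold lower number from compound 2 to compound 3 (0.03 log units; within the scatter) and a 1.8-fold lower number from compound 1 to compound 3 (0.26 log units; within the scatter), lie within the scatter, so the three cannot be placed in order by these numbers.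

Compound 4, `COc1ccc(-c2cc3ccccc3nc2/C=C/C(=O)c2ccc[nH]2)cc1`, differs from compound 3 in a larger way: 1H-pyrrol-2-yl in place of 4-nitrophenyl on a carbonyl carbon. The measured steps each exchange only one substituent on that aromatic ring, as in a 1.7-fold lower number from compound 1 to compound 2 (0.24 log units; within the scatter), and none of them changes the ring itself. They therefore bear on the new step only loosely, showing that changes at this end of the molecule have so far stayed within the scatter. On that basis no step beyond the scatter is expected, and the estimated step is a 1.4-fold higher number from compound 3 to compound 4 (0.15 log units; within the scatter). Compound 4 is expected to give about 1100 nM in this assay, within a range of 400 nM to 3500 nM.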

Compound 4, half-maximal inhibitory concentration: > 10000 nM
Compound 4 gave a limit, no number; the forecaster's own chance of this, stated with the estimate: 5%; middle value at least 9.0-fold (0.95 log units) from the limit.
By their numbers in this assay, from the lowest: compounds 3, 2 and 1 (each within the scatter of the next). At a limit, above all of these: compound 4.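

Exchanging a substituent on the aromatic ring at the carbonyl carbon had stayed within the scatter, but exchanging the ring itself for 1H-pyrrol-2-yl does not in this assay (an at least 12-fold higher number from compound 3 to compound 4 (1.11 log units; beyond the scatter) and an at least 12-fold higher number from compound 2 to compound 4 (1.08 log units; beyond the scatter) and an at least 7.0-fold higher number from compound 1 to compound 4 (0.85 log units; beyond the scatter)). Among these four compounds, then, this position accepts the substituents shown on the six-membered ring, yet activity falls away once that ring gives way to the five-membered ring with its hydrogen-bond donor. Compound 4 gives a limit and not a number, so these steps are minimum sizes: the limit of > 10000 nM in this assay, at which 1 of the 4 values shown sits.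

The compounds shown do not separate the change in ring size from the presence of the ring nitrogen and its hydrogen, which a thiophene or an N-methylpyrrole ring would address. Going by these compounds, how an amine or a carboxylic acid on the phenyl ring would behave also remains open.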